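The source may report more compounds than this note shows. Statements on the series, on what has been measured and on what is new or still open speak of the compounds shown alone.

Cytotoxicity is measured here in an ADME assay on KB cells (Homo sapiens) for cytotoxicity, with a stated time of 48 h; on this read-out higher numbers stand for weaker inhibition and lower numbers for stronger inhibition. In this test, compound 1 `CC1=CCC[C@](C)(CC/C(C)=C/CC2=C(O)C(=O)C=C(N[C@H](C(=O)O)[C@@H](C)O)C2=O)[C@@H]1C` gives > 10 ug/mL, which is a limit of the assay and not a number. Compound 2 `CC1=CCC[C@](C)(CC/C(C)=C/CC2=C(O)C(=O)C=C(N[C@@H](C(=O)O)[C@@H](C)O)C2=O)[C@@H]1C` gives > 10 ug/mL, which is also a limit, so its standing is known only as a limit and not as an exact value.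

Compound 3 `CC1=CCC[C@](C)(CC/C(C)=C/CC2=C(O)C(=O)C=C(N[C@@H](CO)C(=O)O)C2=O)[C@@H]1C` carries 1-carboxy-2-hydroxyethyl in place of 1-carboxy-2-hydroxypropyl on an amine nitrogen.

Going by the values given here, only one measured step is available, a step that the two limits leave unreadable from compound 1 to compound 2. It gives little guidance, as it concerns (the fact that compounds 1 and 2 differ only in the configuration as drawn), not a change of group. All that can be said of the values is the limit of > 10 ug/mL in this assay, at which 2 of the 2 values shown sit. Among the compounds with values here, no step of readable size therefore supports a shift in either direction, and none beyond the usual scatter is expected in this assay.

The expected change is an estimated step that the limit leaves unreadable from compound 2 to compound 3, and the result may well arrive as a limit again.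

In this assay the estimated value for compound 3 is 15 ug/mL, with an expected range from 7 ug/mL to 40 ug/mL.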

Compound 3, half-maximal inhibitory concentration: > 10 ug/mL
Compound 3: only a limit was reported; the forecaster's own chance of this, stated with the estimate: 80%; the middle value is on the limit's open side.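

In this assay, compound 3 gives > 10 ug/mL, which is a limit of the assay and not a number. The steps to it from compound 1 and compound 2 therefore cannot be read. Still open is whether the configuration as drawn, or 1-carboxy-2-hydroxyethyl in place of 1-carboxy-2-hydroxypropyl, changes the read-out at all, since the only result shared by these compounds is: the limit of > 10 ug/mL in this assay, at which 3 of the 3 values shown sit.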